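The compounds below may be only part of what the source reports. "The series", "measured", "known", "first", "only" and "open" are said of these compounds alone.

Within the data shown here, compound 3 `COc1ccc(C(=O)Nc2ccncc2Cl)cc1OC1CCCC1` stands lowest among the three compounds measured so far in an assay on isolated protein for inhibition of phosphodiesterase 4A (Sus scrofa); on this read-out lower numbers stand for stronger inhibition and higher numbers for weaker inhibition: compound 3 gives 16 nM. Compound 1 `COc1ccc(C(=O)Nc2c(F)cccc2F)cc1OC1CCCC1` gives 70 nM in this assay, and compound 2 `COc1ccc(C(=O)Nc2c(F)cccc2Cl)cc1OC1CCCC1` gives 240 nM. The steps leading to compound 3 are both beyond the scatter: a 4.4-fold lower number from compound 1 to compound 3 (0.64 log units; beyond the scatter) and a 15-fold lower number from compound 2 to compound 3 (1.18 log units; beyond the scatter), while a 3.4-fold higher number from compound 1 to compound 2 (0.54 log units; beyond the scatter).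

Compound 4 `COc1ccc(C(=O)Nc2ncccc2C)cc1OC1CCCC1` differs from compound 3 by 3-methylpyridin-2-yl in place of 3-chloropyridin-4-yl on an amide-type nitrogen. Among the measured compounds shown here, none of the measured steps changes the point of attachment of the ring to the amide-type nitrogen or replaces a chlorine by a methyl, so no step bears directly on this change. The measured steps show only that this assay responds to the ring on the amide-type nitrogen, and that its response can be modest or large. The expectation is a modest move toward a higher number, with wide uncertainty: a 5.0-fold higher number from compound 3 to compound 4 (0.70 log units; beyond the scatter). Compound 4 is estimated at 80 nM, with a range from 20 nM to 320 nM.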

Compound 4, half-maximal inhibitory concentration: 3100 nM
The estimate for compound 4 lay 39-fold (1.59 log units) below the measured number; measured number outside the range, above it.
By their numbers in this assay, from the lowest: compound 3; then compound 1; then compound 2; then compound 4.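

Among these compounds, the new result shows that, in this assay, the ring on the amide-type nitrogen can move the number much further than the earlier compounds indicated (a 190-fold higher number from compound 3 to compound 4 (2.29 log units; beyond the scatter)). Compound 4 also lies well above the two compounds with a substituted phenyl ring on that nitrogen (a 13-fold higher number from compound 2 to compound 4 (1.11 log units; beyond the scatter); a 44-fold higher number from compound 1 to compound 4 (1.65 log units; beyond the scatter)), so a six-membered aromatic ring with 1 hetero atom does not by itself give the lowest number, as compound 3 and compound 4 both carry one. Nothing given here accounts for the size of this change.

The change from compound 3 to compound 4 alters both the ring's point of attachment and its substituent, chlorine to methyl, and the compounds shown do not separate the two. As far as these compounds go, the 3-methylpyridin-4-yl and 3-chloropyridin-2-yl groups, each differing from compound 3 or compound 4 in only one of these, remain open.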